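The source may hold more compounds than are shown below. What is called first, only, known or untested is meant among the compounds shown, and "the series" means these compounds.

Measured compounds:
- Compound 1 `CN(C)CCn1cnnc1-c1cc(Oc2ccc(NC(=O)N/N=C/c3c(Cl)cccc3Cl)cc2F)ccn1` gives 160 nM in a functional assay on MKN-45 cells (Homo sapiens) for cytotoxicity, read by MTT assay, with a stated time of 72 h; a higher number here means a weaker inhibitor, a lower number a stronger inhibitor.
- Compound 2 `CN(C)CCn1cnnc1-c1cc(Oc2ccc(NC(=O)N/N=C/c3c[nH]c4ccccc34)cc2F)ccn1` gives 790 nM in this assay.
- Compound 3 `CN(C)CCn1cnnc1-c1cc(Oc2ccc(NC(=O)N/N=C/c3ccccc3O[N+](=O)[O-])cc2F)ccn1` gives 1020 nM in this assay.

Among these three, compound 1 holds the lowest number. Its nearest neighbour is compound 2, reached by a 4.9-fold higher number from compound 1 to compound 2 (0.69 log units; beyond the scatter), and the furthest is compound 3, reached by a 6.4-fold higher number from compound 1 to compound 3 (0.80 log units; beyond the scatter); both of those steps lie beyond the scatter, so compound 1 stands as the strongest inhibitor of the measured set. Between compound 2 and compound 3 the step is a 1.3-fold higher number from compound 2 to compound 3 (0.11 log units; within the scatter), which stays within the scatter.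

The unmeasured compound 4 `CN(C)CCn1cnnc1-c1cc(Oc2ccc(NC(=O)N/N=C/c3ccccc3)cc2F)ccn1` is derived from compound 1 by a single change: phenyl in place of 2,6-dichlorophenyl on a carbon with a double bond to nitrogen. The two steps that bear on this are the ones leaving compound 1, since each also replaces the 2,6-dichlorophenyl on the carbon with a double bond to nitrogen, and each raised the number by a modest amount beyond the scatter. Among the measured compounds shown here, no measured step tells what a bare phenyl does at this place, so the expectation rests on the direction shared by compound 2 and compound 3. Compound 4 is therefore expected to give a higher number than compound 1, a step of about a 3.8-fold higher number from compound 1 to compound 4 (0.57 log units; beyond the scatter). The estimate for compound 4 in this assay is 600 nM, with a range from 200 nM to 2000 nM.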

Compound 4, half-maximal inhibitory concentration: 2730 nM
Estimate against measurement, compound 4: 4.6-fold (0.66 log units) below, and the stated range ends below it.
By their numbers in this assay, from the lowest: compound 1; then compounds 2 and 3 (each within the scatter of the next); then compound 4.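

In this assay, the bare phenyl is no neutral reference point: taking away the two chlorine atoms of the 2,6-dichlorophenyl gives a 17-fold higher number from compound 1 to compound 4 (1.23 log units; beyond the scatter) and thus a larger step than either earlier change from compound 1. Phenyl also falls short of the other two groups at this place, with a 2.7-fold higher number from compound 3 to compound 4 (0.43 log units; beyond the scatter) and a 3.5-fold higher number from compound 2 to compound 4 (0.54 log units; beyond the scatter) making compound 4 the weakest inhibitor of the four. Each of the three substituted or fused groups therefore gives a lower number than phenyl on the carbon with a double bond to nitrogen, and 2,6-dichlorophenyl gives the lowest.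

No measured evidence shown here accounts for this order. As far as these compounds go, it also remains open whether a single chlorine, two fluorine atoms or two methyl groups on the phenyl would bring the number back towards that of compound 1.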